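Nitro Substitution on the Benzothiazole Analogue of the Quinolone Series

This account rests on a few compounds, and the source may have more. Where it says the series, first, only, none or still open, it means among the compounds named here.

The series shares one core bearing an ethyl group, a fluorine and a piperazine; the compounds differ in the aromatic group attached to it and in a substituent on that group. Compound 1 `CCn1cc(-c2nc3ccccc3[nH]2)c(=O)c2cc(F)c(N3CCNCC3)cc21` gives 10500 nM in a functional assay on KB cells (Homo sapiens) for cytotoxicity, read by MTT assay, with a stated time of 48 h; on this read-out lower numbers stand for stronger inhibition and higher numbers for weaker inhibition. Compound 2 `CCn1cc(-c2nc3ccccc3s2)c(=O)c2cc(F)c(N3CCNCC3)cc21` gives 28700 nM in this assay; it differs from compound 1 by 1,3-benzothiazol-2-yl in place of 1H-benzimidazol-2-yl on an aromatic carbon, and the step of a 2.7-fold higher number from compound 1 to compound 2 (0.44 log units; beyond the scatter) follows. Compound 3 `CCn1cc(-c2nc3ccc([N+](=O)[O-])cc3[nH]2)c(=O)c2cc(F)c(N3CCNCC3)cc21` carries the change nitro in place of hydrogen on an aromatic carbon relative to compound 1. In this assay compound 3 gives 1100 nM, the step being a 9.5-fold lower number from compound 1 to compound 3 (0.98 log units; beyond the scatter). Of the three measured values, compound 2 has the highest number and compound 3 the lowest, with the steps between them beyond the scatter.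

Compound 4 `CCn1cc(-c2nc3ccc([N+](=O)[O-])cc3s2)c(=O)c2cc(F)c(N3CCNCC3)cc21` is not yet measured. It differs from compound 2 by nitro in place of hydrogen on an aromatic carbon, the same change as that made from compound 1 to compound 3, at the same kind of place on the fused ring. That change was seen once, on the core of compound 1, and gave a 9.5-fold lower number from compound 1 to compound 3 (0.98 log units; beyond the scatter). Going by these compounds, whether it transfers onto the core of compound 2 is unknown from these data, so the expectation rests on a single precedent. Among the measured compounds shown here, compound 4 is expected to show a step of about an 8.2-fold lower number from compound 2 to compound 4 (0.91 log units; beyond the scatter) in this assay, because the only comparable step is a 9.5-fold lower number from compound 1 to compound 3 (0.98 log units; beyond the scatter). On that basis compound 4 is estimated at 3500 nM, within 1200 nM to 12000 nM.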

Compound 4, half-maximal inhibitory concentration: 700 nM
The estimate for compound 4 lay 5.0-fold (0.70 log units) above the measured number, and the stated range ends above it.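

In this assay the change of nitro in place of hydrogen, carried onto the second core, gives a 41-fold lower number from compound 2 to compound 4 (1.61 log units; beyond the scatter), so the direction seen on the core of compound 1 holds on both cores shown. The size of the step does not carry over unchanged, and the gap between the two steps is a real one in these data: the same change on two cores in this assay, a 9.5-fold lower number (0.98 log units; beyond the scatter) from compound 1 to compound 3 and a 41-fold lower number (1.61 log units; beyond the scatter) from compound 2 to compound 4, 4.3-fold (0.63 log units) apart, beyond the scatter of two such steps. Among the compounds shown here, this pair of steps supports using the change as a guide to direction across these two cores, but not reading the size of the step on one core as its size on the other; with only two cores, it also does not show why the sizes part or what the change would do on any further core.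

Open, going by these compounds, is whether another group in the same place, such as an amine, a methoxy group or a carboxylic acid, would follow nitro in direction and show the same dependence on the core. Also open, on these data alone, is whether nitro keeps this behaviour at another carbon of the same six-membered ring, or with a longer chain in place of the ethyl group.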